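Working notes: 4-methoxyphenyl in place of iodo, compound 3

The source may report more compounds than this note shows. Statements on the series, on what has been measured and on what is new or still open speak of the compounds shown alone.

Measured in an ADME assay on WI-38 cells (Homo sapiens) for cytotoxicity, read by MTT assay, with a stated time of 72 h; on this read-out higher numbers stand for weaker inhibition and lower numbers for stronger inhibition:
Compound 1 `O=C(CCc1cccc2c1B(O)OC2)Nc1ccc(Cl)cc1`: > 100000 nM (a limit of the assay)
Compound 2 `O=C(CCc1cccc2c1B(O)OC2)Nc1ccc(Br)cc1`: 42000 nM
Compound 3 `O=C(CCc1cccc2c1B(O)OC2)Nc1cccc(I)c1`: 71000 nM

Among the compounds with values here, compound 3 has only one neighbour with a true number, and the gap lies within the scatter: a 1.7-fold higher number from compound 2 to compound 3 (0.23 log units; within the scatter). Compound 4 `COc1ccc(-c2cccc(NC(=O)CCc3cccc4c3B(O)OC4)c2)cc1` carries 4-methoxyphenyl in place of iodo on an aromatic carbon, meta to a large group: 4-methoxyphenyl in place of iodo on an aromatic carbon.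

Within the data shown here, no measured step puts a ring at this place, so the evidence is indirect. The only step shown beyond the scatter is a change of halogen, an at least 2.3-fold lower number from compound 1 to compound 2 (0.37 log units; beyond the scatter). The move to 3-iodophenyl gives an at least 1.4-fold lower number from compound 1 to compound 3 (0.14 log units; that floor lies within the scatter), a floor within the scatter. No step beyond the scatter is therefore expected in this assay, and the expectation stays close to compound 3 at 71000 nM. The expected step is a 1.6-fold lower number from compound 3 to compound 4 (0.20 log units; within the scatter). For compound 4 the estimate is 45000 nM, with an expected range of 14000 nM to 100000 nM.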

Compound 4, half-maximal inhibitory concentration: 1400 nM
Beside the measured number, compound 4's estimate is 32-fold (1.51 log units) above it, and the stated range ends above it.
By their numbers in this assay, from the lowest: compound 4; then compounds 2 and 3 (each within the scatter of the next). At a limit, above all of these: compound 1.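

In this assay, the aromatic carbon meta to a large group proves sensitive to what it carries: 4-methoxyphenyl in place of iodo gives a 51-fold lower number from compound 3 to compound 4 (1.71 log units; beyond the scatter), whereas the change from 4-bromophenyl to 3-iodophenyl gives a 1.7-fold higher number from compound 2 to compound 3 (0.23 log units; within the scatter). A lower number here stands for stronger inhibition of these cells, so a six-membered aromatic ring at this place counts as a cytotoxicity flag for the series. Of the compounds shown, only compound 1 is a limit and not a number, and this step does not rest on it: the limit of > 100000 nM in this assay, at which 1 of the 4 values shown sits.

On these data alone, it remains open whether the step belongs to the added ring itself or to its methoxy group. A plain phenyl at the same place, or a ring bearing an amine or a carboxylic acid instead of methoxy, would separate the two.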